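Swapping the thiazole for a dimethyl isoxazole

The compounds below may be only part of what the source reports. "The series", "measured", "known", "first", "only" and "open" are said of these compounds alone.

Of the compounds shown here, three sharing one core have been measured in a physicochemical assay for lipophilicity, read by HPLC, in phosphate buffer, measured as chromatographic lipophilicity, at pH 7.4; a higher number here means a more lipophilic compound, a lower number a more polar compound. Compound 1 `COc1ccc2nc(C)cc(OCC(=O)Nc3cccc(C)c3)c2c1` gives 4.83. Compound 2 `COc1ccc(NC(=O)COc2cc(C)nc3ccc(OC)cc23)cc1` gives 4.22. Compound 3 `COc1ccc2nc(C)cc(OCC(=O)Nc3nccs3)c2c1` gives 3.2, the lowest of the three numbers. The steps between them all change the group on the amide-type nitrogen: a number 0.61 log units lower from compound 1 to compound 2 (beyond the scatter), a number 1.63 log units lower from compound 1 to compound 3 (beyond the scatter) and a number 1.02 log units lower from compound 2 to compound 3 (beyond the scatter). Compound 3 thus stands clearly apart from the other two, further from compound 1 than from compound 2.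

Compound 4 `COc1ccc2nc(C)cc(OCC(=O)Nc3noc(C)c3C)c2c1` has not yet been measured. It differs from compound 3 in one place: 4,5-dimethyl-1,2-oxazol-3-yl in place of 1,3-thiazol-2-yl on an amide-type nitrogen. Within the data shown here, none of the measured steps repeats this exchange; the nearest are the two that bring the 1,3-thiazol-2-yl group in, a number 1.63 log units lower from compound 1 to compound 3 (beyond the scatter) and a number 1.02 log units lower from compound 2 to compound 3 (beyond the scatter), both large, and both in the direction of a lower number. The new group is again a five-membered aromatic ring with 2 hetero atoms, now carrying two methyl groups, so the step from compound 3 to compound 4 is expected to be smaller than either of those and to run upward, a number 0.50 log units higher from compound 3 to compound 4 (beyond the scatter). In this assay compound 4 is therefore estimated at 3.7, within a range from 3.2 to 4.2.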

Compound 4, distribution coefficient: 3.3
The estimate for compound 4 lay 0.40 log units above the measured number; measured number inside the range.
By their numbers in this assay, from the lowest: compounds 3 and 4 (each within the scatter of the next); then compound 2; then compound 1.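

In this assay, the exchange at the amide-type nitrogen gives a number 0.10 log units higher from compound 3 to compound 4 (within the scatter) and so leaves compound 3 and compound 4 indistinguishable, even though the entering 4,5-dimethyl-1,2-oxazol-3-yl group differs from 1,3-thiazol-2-yl in its ring atoms and carries two methyl groups. The steps of a number 0.92 log units lower from compound 2 to compound 4 (beyond the scatter) and a number 1.53 log units lower from compound 1 to compound 4 (beyond the scatter) place compound 4 with compound 3 under both compounds that carry a substituted phenyl group, so among these four compounds the two groups with a five-membered aromatic ring share the low end of the scale and no compound goes against this. Nothing available here explains why these two different groups give such similar numbers.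

The compounds shown leave open how much of this result belongs to the ring itself and how much to its methyl groups, a question that a 1,2-oxazol-3-yl group without methyl groups or a 1,3-thiazol-2-yl group bearing them could help to separate. They also leave open whether the number would stay in this range with an amine or a carboxylic acid on the five-membered ring.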